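Fluoro next to methoxy in the urea series: cytotoxicity

The source may report more compounds than this note shows. Statements on the series, on what has been measured and on what is new or still open speak of the compounds shown alone.

Compound 1 `Cc1cc(NC(=O)Nc2ccc([N+](=O)[O-])c(C(F)(F)F)c2)c2ccccc2n1`, compound 2 `COc1ccc(NC(=O)Nc2cc(C)nc3ccccc23)cc1` and compound 3 `Cc1cc(NC(=O)Nc2ccc(C(=O)O)cc2)c2ccccc2n1` share a urea-linked core and have been run in an ADME assay on BJ cells (Homo sapiens) for cytotoxicity, with a stated time of 72 h; a higher number here means that more compound is needed for the effect, a lower number that less compound is needed. In this assay compound 1 gives only a limit of the assay, > 25000 nM. Compound 2 likewise sits at the limit, > 25000 nM. Compound 3 also reaches only the limit, > 25000 nM. All three readings thus stand at the same point, (the limit of > 25000 nM in this assay, at which 3 of the 3 values shown sit), and compound 2 is not placed by a number but by that limit alone. For the measured compounds named here, the one single-point step, a step that the two limits leave unreadable from compound 2 to compound 3, is left unreadable by the two limits.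

Compound 4 `COc1ccc(NC(=O)Nc2cc(C)nc3ccccc23)cc1F` differs from compound 2 by fluoro in place of hydrogen on an aromatic carbon. Going by the values given here, no measured step bears on this change, and the only comparison available is hidden behind limits. The expectation for compound 4 therefore rests on compound 2 being at the limit, > 25000 nM, with a step that the limit leaves unreadable from compound 2 to compound 4 expected. Compound 4 is estimated at 30000 nM, in the range 15000 nM to 60000 nM.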

Compound 4, half-maximal effective concentration: 26000 nM
The estimate for compound 4 lay 1.2-fold (0.06 log units) above the measured number, within the range that was stated.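

In this assay, for the compounds shown here, compound 2 gives only a limit of the assay, > 25000 nM, so no step from it to compound 4 can be read. The compounds shown leave open what fluoro in place of hydrogen does to the reading; compound 4 alone carries a number.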